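The source may report more compounds than this note shows. Statements on the series, on what has been measured and on what is new or still open speak of the compounds shown alone.

Measured compounds:

Compound 1 `CCCCCCCCCCn1cc(-c2nc3ccccc3cc2CCCC)nn1`. In a functional assay on HeLa cells (Homo sapiens) for cytotoxicity, read by MTT assay, with a stated time of 24 h (on this read-out lower numbers stand for stronger inhibition and higher numbers for weaker inhibition), compound 1 gives only a limit, > 100 ug/mL.
Compound 2 `CCCCCCCCCCn1cc(-c2nc3ccccc3cc2CCC)nn1`. In this assay compound 2 gives only a limit, > 100 ug/mL.
Compound 3 `CCc1cc2ccccc2nc1-c1cn(CCC(F)(F)C(F)(F)C(F)(F)C(F)(F)C(F)(F)C(F)(F)C(F)(F)C(F)(F)F)nn1`. In this assay compound 3 gives only a limit, > 100 ug/mL.

Compound 1 and compound 2 share a core and differ by one change, (methyl in place of hydrogen on a saturated chain carbon, three bonds along the chain from an aromatic carbon). Both of them sit at a limit of this assay, so the step that the two limits leave unreadable from compound 2 to compound 1 cannot be read; the limit of > 100 ug/mL in this assay, at which 3 of the 3 values shown sit, is the whole of what is known of the pair.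

Compound 3 carries a different core and a different chain on the ring nitrogen; the difference between the two cores is not broken down here. All three measured values sit at the same limit, (the limit of > 100 ug/mL in this assay, at which 3 of the 3 values shown sit), and none of them gives a number.

Not yet measured is compound 4 `CCCc1cc2ccccc2nc1-c1cn(CCC(F)(F)C(F)(F)C(F)(F)C(F)(F)C(F)(F)C(F)(F)C(F)(F)C(F)(F)F)nn1`. It differs from compound 3 by methyl in place of hydrogen on a saturated chain carbon, two bonds along the chain from an aromatic carbon. This is the same kind of change as that from compound 2 to compound 1, not the same: there the place is three bonds along the chain from an aromatic carbon, here it is two bonds along the chain from an aromatic carbon.

The step from compound 3 to compound 4 in this assay is expected to be small, a step that the limit leaves unreadable from compound 3 to compound 4, resting on the unreadable step that the two limits leave unreadable from compound 2 to compound 1 and on compound 3 sitting at > 100 ug/mL. Compound 4 is therefore expected to give 200 ug/mL in this assay, most likely again reported only as a limit, within an estimated range from 80 ug/mL to 600 ug/mL.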

Compound 4, half-maximal inhibitory concentration: 37.8 ug/mL
Compound 4: middle estimate off by 5.3-fold (0.72 log units), on the high side; the measured number lies below the stated range.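

Methyl in place of hydrogen on a saturated chain carbon, two bonds along the chain from an aromatic carbon, gives an at least 2.6-fold lower number from compound 3 to compound 4 (0.42 log units; beyond the scatter) in this assay; this is a real drop beyond the scatter, and its printed size is only a minimum, as the starting value is a limit and not a number. On the other core, with a different chain on the ring nitrogen and the change three bonds along the chain from an aromatic carbon, the step cannot be read, so compound 1 and compound 2 neither support nor contradict a transfer of the change between cores: the limit of > 100 ug/mL in this assay, at which 3 of the 4 values shown sit. One readable pair therefore shows that the change can matter on the core of compound 3, but not that it carries to another core, and it gives no cause for the step.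

Open, as far as these compounds go, is whether a longer chain than propyl at this place, or an amine or a carboxylic acid in place of the propyl group, would give a lower number still. Also open, from the compounds shown here alone, is what the chain on the ring nitrogen contributes: compound 2 and compound 4 both carry propyl with different chains there, and only compound 4 gives a number.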